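Pyroglutamide series: removing the lactam benzyl group

The compounds below may be only part of what the source reports. "The series", "measured", "known", "first", "only" and "open" are said of these compounds alone.

Measured so far:
compound 1 `CC1(C)OB(c2ccc(COc3ccc(CNC(=O)[C@@H]4CCC(=O)N4Cc4ccccc4)cc3)cc2)OC1(C)C`: 50 nM
compound 2 `O=C(NCc1ccc(OCc2ccccc2)cc1)[C@@H]1CCC(=O)N1Cc1ccccc1`: > 5000 nM
compound 3 `O=C(O)c1ccc(COc2ccc(CNC(=O)[C@@H]3CCC(=O)N3Cc3ccccc3)cc2)cc1`: 4500 nM

In an assay on HEK293 cells for inhibition of Ataxin-2 (Mus musculus), read by fluorescence and Amplex Red (a higher number here means a weaker inhibitor, a lower number a stronger inhibitor), compound 1 gives 50 nM. For compound 2 this assay reports only a limit, > 5000 nM, and not a number. Compound 3 gives 4500 nM in this assay, the highest of the two numbers shown; the nearest number is that of compound 1, and the step of a 90-fold higher number from compound 1 to compound 3 (1.95 log units; beyond the scatter) is large. The step of an at least 100-fold higher number from compound 1 to compound 2 (2.00 log units; beyond the scatter) is likewise large, and an at least 1.1-fold lower number from compound 2 to compound 3 (0.04 log units; that floor lies within the scatter) stays within the scatter.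

Compound 4 `O=C1CC[C@@H](C(=O)NCc2ccc(OCc3ccc(C(=O)O)cc3)cc2)N1` differs from compound 3 by hydrogen in place of benzyl on an amide-type nitrogen in a ring. On these data alone, all three measured steps concern the other end of the shared core, so none of them bears on this change, and the effect of the benzyl group on the ring nitrogen is untested. With compound 3 already close to the limit at which compound 2 sits (the limit of > 5000 nM in this assay, at which 1 of the 3 values shown sits), the expectation for compound 4 is a number near that of compound 3, 6000 nM with a range from 2000 nM to 20000 nM, corresponding to an estimated step of a 1.3-fold higher number from compound 3 to compound 4 (0.12 log units; within the scatter) that is not expected to exceed the scatter, with a real chance that this assay reports only a limit.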

Compound 4, half-maximal inhibitory concentration: > 5000 nM
Compound 4: only a limit was reported; the forecaster's own chance of this, stated with the estimate: 55%; the middle value is on the limit's open side.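

For compound 4, this assay reports only a limit, > 5000 nM. Hydrogen in place of benzyl on the amide-type nitrogen in a ring gives an at least 1.1-fold higher number from compound 3 to compound 4 (0.04 log units; that floor lies within the scatter), so this first change at that nitrogen brings no lower number on the carboxy-bearing background, while the true size of the step stays unread. The series now has a second compound that cannot be ranked by a number: the limit of > 5000 nM in this assay, at which 2 of the 4 values shown sit.

Still open, on these data alone, is what the same change does on the background of compound 1, which gives 50 nM and leaves room for a step to be read in full. Also open, as far as these compounds go, is how a methyl group or a longer alkyl chain on that ring nitrogen compares with benzyl and with hydrogen.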